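This account rests on a few compounds, and the source may have more. Where it says the series, first, only, none or still open, it means among the compounds named here.

Measured so far in an ADME assay on HEK-293T cells (Homo sapiens) for inhibition, read by CCK-8 assay, with a stated time of 48 h, tested at 20 uM; on this read-out higher numbers stand for more inhibition of growth at the one concentration tested and lower numbers for less inhibition of growth:
- compound 1 `COc1ccc(S(=O)(=O)Oc2ccccc2/C=C(\C#N)C(=O)Nc2nnc(-c3cccs3)s2)cc1` gives 40%
- compound 2 `COc1ccc(S(=O)(=O)Oc2ccccc2/C=C(\C#N)C(=O)Nc2nnc(Cc3ccccc3)s2)cc1` gives 23%

Compound 2 holds the lower of the two numbers. Compound 3 `COc1ccc(S(=O)(=O)Oc2ccccc2/C=C(\C#N)C(=O)Nc2nnc(Cc3ccc(F)cc3)s2)cc1` differs from it by one small edit, fluoro in place of hydrogen on an aromatic carbon, para to a large group, turning benzyl into 4-fluorobenzyl fluoro in place of hydrogen on an aromatic carbon in the structure. Going by the values given here, the only measured step, a number 17 percentage points lower from compound 1 to compound 2 (beyond the scatter), swaps a whole group at the same end of the molecule, and no measured step adds a fluoro, so it offers only a loose guide. The expected change is small, a number 2 percentage points higher from compound 2 to compound 3 (within the scatter), with nothing expected beyond the scatter. Compound 3 is therefore estimated at 25% (expected range 12% to 40%).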

Compound 3, percent growth inhibition at one concentration: 20%
Compound 3: middle estimate off by 5 percentage points, on the high side, within the range that was stated.
By their numbers in this assay, from the lowest: compounds 3 and 2 (each within the scatter of the next); then compound 1.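

In this assay the fluoro on the aromatic carbon para to a large group, which turns benzyl into 4-fluorobenzyl, gives a number 3 percentage points lower from compound 2 to compound 3 (within the scatter) and so does not separate these two compounds. Replacing thiophen-2-yl with 4-fluorobenzyl gives a number 20 percentage points lower from compound 1 to compound 3 (beyond the scatter) and so shows a gap much larger than the one left by the fluoro edit. No measurement shown here explains either result.

As far as these compounds go, whether a different group in the same place, such as chloro, an amine or a carboxylic acid, would move the number beyond the scatter stays open.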